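The source may report more compounds than this note shows. Statements on the series, on what has been measured and on what is new or still open speak of the compounds shown alone.

Working notes on the series. The three measured compounds share one core and differ only at the carbonyl carbon attached to the amide-type nitrogen in the ring. Compound 1 `Cc1nc(S(C)(=O)=O)ccc1Oc1ncnc(OC2CCN(C(=O)OC(C)F)CC2)c1F` gives 315 nM in a functional assay on isolated protein for inhibition of Glucose-dependent insulinotropic receptor (Rattus norvegicus), read by HTRF and cAMP accumulation; on this read-out higher numbers stand for an effect only at larger amounts of compound and lower numbers for an effect already at smaller amounts. Compound 2 `Cc1nc(S(C)(=O)=O)ccc1Oc1ncnc(OC2CCN(C(=O)OC3(C(F)(F)F)CCC3)CC2)c1F` gives 63.3 nM in this assay, the step being a 5.0-fold lower number from compound 1 to compound 2 (0.70 log units; beyond the scatter). Compound 3 `CCC(F)(F)C(=O)N1CCC(Oc2ncnc(Oc3ccc(S(C)(=O)=O)nc3C)c2F)CC1` gives 69.2 nM in this assay; the steps to it are a 4.6-fold lower number from compound 1 to compound 3 (0.66 log units; beyond the scatter) and a 1.1-fold higher number from compound 2 to compound 3 (0.04 log units; within the scatter). Compound 3 thus stands second highest of the three numbers, with compound 2 nearest and compound 1 furthest.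

Compound 4 `Cc1nc(S(C)(=O)=O)ccc1Oc1ncnc(OC2CCN(C(=O)c3noc(C(C)(C)F)n3)CC2)c1F` differs from compound 3 by a group of 9 heavy atoms (5 carbon, 2 nitrogen, 1 oxygen, 1 fluorine; one five-membered aromatic ring with 3 hetero atoms) in place of a group of 5 heavy atoms (3 carbon, 2 fluorine; no ring), on a carbonyl carbon. The step that bears most directly on a ring-containing group replacing the 1,1-difluoropropyl at this carbonyl carbon is a 1.1-fold higher number from compound 2 to compound 3 (0.04 log units; within the scatter), which stayed within the scatter; the larger step of a 4.6-fold lower number from compound 1 to compound 3 (0.66 log units; beyond the scatter) concerns a different pair of groups. Since compound 2, carrying a ring-containing group at this carbon, gives 63.3 nM, the expected step for compound 4 is a 1.1-fold lower number from compound 3 to compound 4 (0.03 log units; within the scatter), not beyond the scatter. Compound 4 is therefore estimated at 65 nM in this assay, with a range from 20 nM to 220 nM.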

Compound 4, half-maximal effective concentration: 103 nM
Beside the measured number, compound 4's estimate is 1.6-fold (0.20 log units) below it, and the stated range covers the measured number.
By their numbers in this assay, from the lowest: compounds 2, 3 and 4 (each within the scatter of the next); then compound 1.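

At this carbonyl carbon, in this assay, the five-membered aromatic ring group with 3 hetero atoms replaces 1,1-difluoropropyl with a 1.5-fold higher number from compound 3 to compound 4 (0.17 log units; within the scatter), and replaces the four-membered carbon ring group with a 1.6-fold higher number from compound 2 to compound 4 (0.21 log units; within the scatter), so an aromatic ring group here stays level with both an open chain and a non-aromatic ring group. Compound 2 and compound 3 each stand apart from compound 1 beyond the scatter. The same separation holds for the aromatic ring group, with a 3.1-fold lower number from compound 1 to compound 4 (0.49 log units; beyond the scatter). No measurement at hand accounts for any of these steps.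

As far as these compounds go, whether an amine, a carboxylic acid or a longer chain on this carbonyl carbon keeps the number at this level stays open. Also open, from the compounds shown here alone, is what the aromatic ring and its fluorine-bearing substituent each contribute, as the two enter together.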